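A few compounds are considered here, and "the series" means these few. Any claim that something is new, unique, unknown or untested is made for them only; others in the source may bear on it.

Measured so far in a functional assay on PC-3 cells (Homo sapiens) for cytotoxicity, read by MTT assay, with a stated time of 48 h; on this read-out lower numbers stand for stronger inhibition and higher numbers for weaker inhibition:

Compound 1 `O=C(O)CN1C(=O)/C(=C/c2nc3ccccc3n2Cc2ccc(F)cc2)SC1=S` gives 4860 nM.
Compound 2 `O=C(O)CN1C(=O)/C(=C/c2nc3ccccc3n2Cc2ccc(Cl)cc2)SC1=S` gives 9670 nM.
Compound 3 `Cc1ccc(Cn2c(/C=C3\SC(=S)N(CC(=O)O)C3=O)nc3ccc(Cl)cc32)cc1` gives 1520 nM.

Compound 1 and compound 2 share one core and differ by fluoro in place of chloro on an aromatic carbon. That single exchange gives a 2.0-fold lower number from compound 2 to compound 1 (0.30 log units; within the scatter), so the two values cannot be ordered with confidence. Compound 3 carries a different core; the difference between the two cores is not broken down here. Compound 3 stands lowest of the three values, and its nearest neighbour is compound 1, with a gap beyond the scatter, while compound 2 lies further off.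

Compound 4 `Cc1ccc(Cn2c(/C=C3\SC(=S)N(CC(=O)O)C3=O)nc3ccc(F)cc32)cc1` is not yet measured. It differs from compound 3 by fluoro in place of chloro on an aromatic carbon. This is the same kind of change as that between compound 2 and compound 1, but not the same: in compound 4 the exchange sits on an aromatic carbon of a six-membered aromatic ring of carbon only, part of a fused or bridged system of two rings, meta to a fused ring and para to a fused ring, whereas in compound 1 it sits on a six-membered aromatic ring of carbon only, para to a large group.

Within the data shown here, the only precedent for this exchange is the step from compound 2 to compound 1, which stayed within the scatter. The expectation for compound 4 is therefore a step of about a 1.3-fold lower number from compound 3 to compound 4 (0.10 log units; within the scatter), resting on that precedent and on compound 3 at 1520 nM. Compound 4 is estimated at 1200 nM, within a range from 500 nM to 3500 nM, the width reflecting that the exchange sits in a different setting in this core.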

Compound 4, half-maximal inhibitory concentration: 5820 nM
The estimate for compound 4 lay 4.9-fold (0.69 log units) below the measured number; the measured number lies above the stated range.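

In this assay fluoro in place of chloro gives a 3.8-fold higher number from compound 3 to compound 4 (0.58 log units; beyond the scatter) and so makes a measurable difference in this core. Among these compounds, only two pairs carry the exchange, and its setting differs: in compound 1 it sits on a six-membered aromatic ring of carbon only, para to a large group, whereas in compound 4 it sits on such a ring within a fused system of two rings, and the cores also differ elsewhere, so the data cannot separate the place of the halogen from the rest of the core and give no reason for the gap. What can be said is limited to these two pairs, where the exchange does not carry over as a step of fixed size from one core to the other: the same change on two cores in this assay, a 2.0-fold lower number (0.30 log units; within the scatter) from compound 2 to compound 1 and a 3.8-fold higher number (0.58 log units; beyond the scatter) from compound 3 to compound 4, 7.6-fold (0.88 log units) apart, beyond the scatter of two such steps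

As far as these compounds go, it remains open whether the step seen on the fused ring system would persist with bromo or methoxy at the same place, which would show whether the result is particular to fluoro and chloro. Also open, from the compounds shown here alone, is how the exchange behaves in either core when the acetic acid chain gives way to a longer propanoic acid chain or an amide.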